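Replacing Hydroxymethyl with Carboxy on the Shared Core

The compounds below may be only part of what the source reports. "The series", "measured", "known", "first", "only" and "open" are said of these compounds alone.

Of the compounds shown here, three on one core have been measured in a functional assay on Maver1 cells (Homo sapiens) for inhibition, read by luminescence and CellTiter-Glo, with a stated time of 72 h; a lower number here means a stronger inhibitor, a higher number a weaker inhibitor. Compound 1 `C=CC(=O)Nc1ccc(Cn2nc(-c3ccc(Oc4ccccc4)cc3)cc2C(=O)O)cc1` gives > 60000 nM in this assay, which is a limit rather than a number. Compound 2 `C/C=C/C(=O)Nc1ccc(Cn2nc(-c3ccc(Oc4ccccc4)cc3)cc2C(=O)O)cc1` likewise gives > 60000 nM in this assay, again a limit. The change from compound 1 to compound 2 is a step that the two limits leave unreadable from compound 1 to compound 2, the prop-1-en-1-yl in place of vinyl on a carbonyl carbon, and nothing can be read from it. For the measured compounds named here, compound 3 `O=C(CCl)Nc1ccc(Cn2nc(-c3ccc(Oc4ccccc4)cc3)cc2CO)cc1`, which carries a hydroxymethyl group and a chloroacetyl amide, gives 400 nM in this assay; it is the only compound with a number, the other two sitting at the limit of > 60000 nM in this assay, at which 2 of the 3 values shown sit.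

Compound 4 `O=C(CCl)Nc1ccc(Cn2nc(-c3ccc(Oc4ccccc4)cc3)cc2C(=O)O)cc1` keeps the chloroacetyl amide of compound 3 and differs from it by carboxy in place of hydroxymethyl on an aromatic carbon, a carboxy in place of hydroxymethyl on an aromatic carbon. Going by the values given here, no measured pair isolates this change, so its size cannot be read from the data. What the data do show is that the two carboxy-bearing compounds 1 and 2 sit at the limit of > 60000 nM in this assay, at which 2 of the 3 values shown sit, whereas the hydroxymethyl compound 3 gives a number. The expected step is therefore a loss, a 38-fold higher number from compound 3 to compound 4 (1.57 log units; beyond the scatter), with a fair chance that only a limit is reported. Compound 4 is estimated at 15000 nM, between 1500 nM and 60000 nM.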

Compound 4, half-maximal inhibitory concentration: 1200 nM
Compound 4: the middle estimate sits 13-fold (1.10 log units) above what was measured, and the stated range ends above it.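

In this assay, the carboxy in place of hydroxymethyl on an aromatic carbon can now be read with the chloroacetyl amide held fixed, and it proves a modest change: a 3.0-fold higher number from compound 3 to compound 4 (0.48 log units; beyond the scatter). Carboxy at this position therefore does not by itself put a compound at the limit, since compound 4 carries it and still gives a number, while with carboxy held fixed the group on the carbonyl carbon marks a much larger difference: chloromethyl in place of prop-1-en-1-yl gives an at least 50-fold lower number from compound 2 to compound 4 (1.69 log units; beyond the scatter), and chloromethyl in place of vinyl gives an at least 50-fold lower number from compound 1 to compound 4 (1.69 log units; beyond the scatter). Compound 1 and compound 2 each stand at a limit and not at a number, so these two steps give only a smallest size: the limit of > 60000 nM in this assay, at which 2 of the 4 values shown sit.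

The compounds shown leave open whether the modest carboxy step holds when the chloromethyl group gives way to vinyl or prop-1-en-1-yl, as no hydroxymethyl compound carrying either group appears here. As far as these compounds go, it also remains open how a methyl ester or a primary amide would compare with carboxy and hydroxymethyl at this position, and whether bromomethyl on the carbonyl carbon would keep a number like that of chloromethyl.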